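Series notes: from compound 3 to compound 4

The compounds below may be only part of what the source reports. "The series", "measured", "known", "first", "only" and "open" are said of these compounds alone.

Three members of the series have numbers in a functional assay on PC-12 cells (Rattus norvegicus) for cytotoxicity, read by MTT assay, with stated times of 3 h and 2 h, tested at 0.1 uM; on this read-out higher numbers stand for a stronger effect at the one concentration tested and lower numbers for a weaker effect. Compound 1 `Cc1cc(=O)oc2cc(OCCCn3cc(CNC(=O)CCCCC4CCSS4)nn3)ccc12` gives 44.8%. Compound 2 `O=C(CCCCC1CCSS1)NCc1cn(CCCOc2ccc3cc(-c4ccc(Cl)cc4)c(=O)oc3c2)nn1` gives 40.9%. Compound 3 `O=C(CCCCC1CCSS1)NCc1cn(CCCCOc2ccc3cc(-c4ccccc4)c(=O)oc3c2)nn1` gives 38.6%, the lowest of the three numbers, but its gap to compound 2 and its gap to compound 1 both lie within the scatter, so the three values cannot be told apart on this read-out.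

Compound 4 `O=C(CCCCC1CCSS1)NCc1cn(CCCCOc2ccc3cc(-c4ccc(Cl)c(Cl)c4)c(=O)oc3c2)nn1` has not been measured. Relative to compound 3 the change is 3,4-dichlorophenyl in place of phenyl on an aromatic carbon. Among the compounds with values here, no pair of measured compounds differs in one place only, so no clean step is available to set a size for a change of this kind; compound 2 carries a chlorine on the same phenyl ring as compound 4 but differs from compound 3 in more than one place, so its number and that of compound 3 show only that the two sit within the scatter of each other.

With all three measured values inside one band, the step from compound 3 to compound 4 in this assay is expected to be a number 1.4 percentage points higher from compound 3 to compound 4 (within the scatter), none beyond the scatter. Compound 4 is estimated at 40%, within a range from 30% to 50%.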

Compound 4, a percentage reported as activity, at one concentration (the size of the read-out at that concentration, not a potency): 39.6%
The estimate for compound 4 lay 0.4 percentage points above the measured number; low and high end bracket the measured number.
By their numbers in this assay, from the lowest: compounds 3, 4, 2 and 1 (each within the scatter of the next).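

In this assay, within the data shown here, this is the first pair that differs in one place only, and 3,4-dichlorophenyl in place of phenyl on the aromatic carbon gives a number 1 percentage points higher from compound 3 to compound 4 (within the scatter), so this step has a size that can be read. At this position, a group of 8 heavy atoms, 2 of them chlorine, thus stands in for one of 6 heavy atoms without a step beyond the scatter, although this rests on a single pair at one concentration and says nothing about other aryl groups. No supporting measurement bears on this result.

The remaining pairs differ in more than one place, so their steps cannot be read, and the contribution of the chain joining the shared core to the triazole-bearing part stays unresolved. Also open, from the compounds shown here alone, is whether a group of a different kind on this aromatic carbon, such as a carboxylic acid or an amine in place of the aryl ring, would give a step beyond the scatter.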